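The source may hold more compounds than are shown below. What is called first, only, known or untested is meant among the compounds shown, and "the series" means these compounds.

Measured so far in a functional assay with Alpha-1A adrenergic receptor (Homo sapiens) as the target, read by calcium flux; a lower number here means a smaller maximal response, a higher number a larger maximal response:
compound 1, `c1ccc(-c2cnccn2)c(OCC2=NCCN2)c1`, gives 97%;
compound 2, `c1ccc(-c2ccns2)c(OCC2=NCCN2)c1`, gives 99%;
compound 3, `c1ccc(-c2nccs2)c(OCC2=NCCN2)c1`, gives 102%.

Compound 1 carries the smallest of the three numbers, but the gaps to the others are small: a number 2 percentage points higher from compound 1 to compound 2 (within the scatter) and a number 5 percentage points higher from compound 1 to compound 3 (within the scatter). The pair compound 2 and compound 3 also sits close, a number 3 percentage points higher from compound 2 to compound 3 (within the scatter). Compound 4, `Cc1ccc(-c2ccccc2OCC2=NCCN2)s1`, differs from compound 1 in one place: 5-methylthiophen-2-yl in place of pyrazin-2-yl on an aromatic carbon. Every measured step is an exchange of the aromatic ring at that same carbon, and none of them moved the maximal response beyond the scatter. A five-membered ring with one sulfur and a methyl group is a further exchange of the same kind, so compound 4 is expected to change little, a number 2 percentage points higher from compound 1 to compound 4 (within the scatter). Compound 4 is therefore estimated at 99%, within 88% to 110%.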

Compound 4, largest response reached (reported as maximum), in percent of the reference or control that the assay uses: 97%
Compound 4: middle estimate off by 2 percentage points, on the high side; the measured number falls inside the stated range.
By their numbers in this assay, from the lowest: compounds 1, 4, 2 and 3 (each within the scatter of the next).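

In this assay the 5-methylthiophen-2-yl group of compound 4 brings a methyl group and a ring without nitrogen to this aromatic carbon, yet all three new steps stay within the scatter (no change at the digits printed from compound 1 to compound 4 (within the scatter)) (a number 2 percentage points lower from compound 2 to compound 4 (within the scatter)) (a number 5 percentage points lower from compound 3 to compound 4 (within the scatter)). Among these four compounds, then, neither that methyl group nor a ring nitrogen separates the maximal responses. No evidence bears on why this is so.

Still open, going by these compounds, is whether an amine, a carboxylic acid or a longer chain at this carbon would move the maximal response beyond the scatter.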